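Adding a Methyl Group to Compound 2

The source may hold more compounds than are shown below. What is called first, only, known or untested is meant among the compounds shown, and "the series" means these compounds.

Three compounds built on a shared core were tested in a functional assay on cells (Tumor Cell line, Homo sapiens) for antiproliferative activity; a higher number here means a weaker inhibitor of growth, a lower number a stronger inhibitor of growth. Compound 1 `Cc1cnc2nc(-c3ccc4ccccc4c3)cc(O)c2c1` gives 741 nM, compound 2 `Cc1ccc2c(O)cc(-c3cccc(Cl)c3)nc2n1` gives 170 nM, and compound 3 `Cc1ccnc2nc(-c3cccc4ccccc34)cc(O)c12` gives 35.5 nM. Compound 2 thus holds the second highest of the three numbers: compound 1 stands beyond the scatter above it, compound 3 beyond the scatter below it. Compound 4 `Cc1cc(C)c2c(O)cc(-c3cccc(Cl)c3)nc2n1` is not yet measured and differs from compound 2 in one place (methyl in place of hydrogen on an aromatic carbon). Within the data shown here, no measured pair here differs in only one place, so the data give no direct guide to the size of such a change. The step is expected to be small, with no clear direction beyond the scatter a 1.3-fold lower number from compound 2 to compound 4 (0.12 log units; within the scatter). Compound 4 is estimated at 130 nM, within a range from 45 nM to 400 nM.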

Compound 4, concentration for 50% growth inhibition: 347 nM
Compound 4: the middle estimate sits 2.7-fold (0.43 log units) below what was measured, within the range that was stated.
By their numbers in this assay, from the lowest: compound 3; then compound 2; then compound 4; then compound 1.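

In this assay, among these compounds, this is the first direct comparison of a single change: putting methyl in place of hydrogen at this position, opposite the ring nitrogen, gives a 2.0-fold higher number from compound 2 to compound 4 (0.31 log units; beyond the scatter). The step is modest, but it shows that this position is not indifferent to substitution and that, on this compound, hydrogen gives the stronger inhibitor of growth. Nothing at hand explains the step. Going by these compounds, whether an ethyl group, an amine or a methoxy group here would raise or lower the number remains open. So does whether methyl would have the same effect in another compound.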